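Trimming a Benzyl to a Phenyl on a Urea Nitrogen

This account rests on a few compounds, and the source may have more. Where it says the series, first, only, none or still open, it means among the compounds named here.

The three measured compounds share a core in which a urea carries a triazole on one nitrogen. In a functional assay on MDA-MB-231 cells (Homo sapiens) for cytotoxicity, read by MTT assay, with a stated time of 48 h (on this read-out lower numbers stand for stronger inhibition and higher numbers for weaker inhibition), compound 1, `COc1cc(CN(C(=O)Nc2cc(C(F)(F)F)cc(C(F)(F)F)c2)n2cnnc2)cc(OC)c1OC`, gives 24900 nM. Compound 3, `COc1ccc(CN(C(=O)Nc2ccc(Cl)c(C(F)(F)F)c2)n2cnnc2)cc1OC`, reaches only a limit of the assay, > 50000 nM. Compound 2, `O=C(NCc1ccccc1)N(Cc1ccccn1)n1cnnc1`, likewise reaches only a limit, > 50000 nM. Thus compound 2 does not stand as a number at all but sits at the limit of > 50000 nM in this assay, at which 2 of the 3 values shown sit, so that nothing beyond weak activity can be read from it. The step to the untested compound 4, `O=C(Nc1ccccc1)N(Cc1ccccn1)n1cnnc1`, is a small one: phenyl in place of benzyl on an amide-type nitrogen, the same nitrogen whose other neighbour is the carbonyl carbon. Among the measured compounds shown here, no pair of measured compounds differs in just this way, so the size of the step can only be guessed. Because compound 2 sits at the limit of > 50000 nM in this assay, at which 2 of the 3 values shown sit, there is no room to see a change for the worse, and the step from compound 2 to compound 4 is expected to be a step that the limit leaves unreadable from compound 2 to compound 4, essentially none beyond the scatter. Compound 4 is therefore estimated at 60000 nM, within a range of 20000 nM to 200000 nM, most likely again reported as a limit.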

Compound 4, half-maximal inhibitory concentration: > 50000 nM
Compound 4: a limit, no number; the forecaster's own chance of this, stated with the estimate: 80%; the middle value is on the limit's open side.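

Compound 2 and compound 4 both reach only a limit of the assay and give no number, so no step between them can be read: the limit of > 50000 nM in this assay, at which 3 of the 4 values shown sit.

The compounds shown leave open whether phenyl in place of benzyl on an amide-type nitrogen changes activity at all in this assay, and how large any such change would be.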